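Notes on the carbonyl-bound group in the sulfonamide series

The source may hold more compounds than are shown below. What is called first, only, known or untested is meant among the compounds shown, and "the series" means these compounds.

The compounds share one core, seen in compound 1 `O=C(NCc1ccc(CNS(=O)(=O)c2cccc(F)c2)cc1)c1cc2ccccn2n1`, in which an aromatic group sits on a carbonyl carbon, followed by an amide, a linker and an aryl sulfonamide. In an assay on cells for displacement of a labelled ligand from C-X-C chemokine receptor type 4 (Homo sapiens), read by fluorescence and microscopy, with stated times of 10 min and 30 min (a lower number here means that less compound is needed, a higher number that more compound is needed for the effect), compound 1 gives 1000 nM. Compound 2 `O=C(NCc1ccc(CNS(=O)(=O)c2ccc(F)c(F)c2)cc1)c1cnc2ccccn12` carries a different group on the carbonyl and a different aryl on the sulfonamide. For compound 2 this assay reports only a limit, > 1000 nM, and not a number. Compound 3 `Cn1nccc1C(=O)NCc1ccc(CNS(=O)(=O)c2ccc3c(c2)CCO3)cc1` gives 1000 nM in this assay, level with compound 1 at the digits shown and within the scatter of it.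

Compound 4 `O=C(NCc1ccc(CNS(=O)(=O)c2ccc3c(c2)CCO3)cc1)c1cc2ccccn2n1` keeps the sulfonamide side of compound 3 and changes only the group on the carbonyl carbon: a group of 9 heavy atoms (7 carbon, 2 nitrogen; one five-membered aromatic ring with 2 hetero atoms, one six-membered aromatic ring with 1 hetero atom) in place of a group of 6 heavy atoms (4 carbon, 2 nitrogen; one five-membered aromatic ring with 2 hetero atoms), on a carbonyl carbon. For the measured compounds named here, the group that enters is the one carried by compound 1, which with another sulfonamide aryl gave 1000 nM. Going by the values given here, no measured pair isolates this change, so the expectation rests on compound 1 and compound 3 sitting at the same number. The expected step from compound 3 to compound 4 in this assay is none beyond the scatter, no change at the digits printed from compound 3 to compound 4 (within the scatter). Compound 4 is therefore estimated at 1000 nM, with a range from 400 nM to 3000 nM. Because one of the three values is a limit, (the limit of > 1000 nM in this assay, at which 1 of the 3 values shown sits), a limit rather than a number is possible for compound 4 as well.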

Compound 4, effective concentration (reported as EC, without a stated level of effect): 1 nM
Beside the measured number, compound 4's estimate is 1000-fold (3.00 log units) above it; measured number below the stated range.
By their numbers in this assay, from the lowest: compound 4; then compounds 1 and 3 (each within the scatter of the next).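

With the sulfonamide side held fixed, replacing 1-methyl-1H-pyrazol-5-yl on the carbonyl carbon with the two-ring group of 9 heavy atoms gives a 1000-fold lower number from compound 3 to compound 4 (3.00 log units; beyond the scatter) in this assay, so this position responds strongly to the change. With that two-ring group held fixed, changing the group on the sulfonyl sulfur gives a 1000-fold lower number from compound 1 to compound 4 (3.00 log units; beyond the scatter), so the result also depends on the aryl at the other end of the molecule. Neither compound 1 nor compound 3 carries both of the groups found in compound 4, and the two single-place steps show that, within these compounds, the low number appears only where those groups occur together.

Nothing measured here gives a cause for either step. The compounds shown leave open whether the effect of the two-ring group depends on this particular sulfonamide aryl more widely, and whether an amine or a carboxylic acid on that group, or a longer chain in place of the linker, would keep the number of compound 4.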